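The source may hold more compounds than are shown below. What is called first, only, known or untested is meant among the compounds shown, and "the series" means these compounds.

Measured so far in an assay on CHO cells for antagonist activity at transient receptor potential cation channel subfamily V member 1 (Homo sapiens), read by FLIPR; a higher number here means a weaker inhibitor, a lower number a stronger inhibitor:

Compound 1, `CC(C(=O)NCc1ccc(C(F)(F)F)cc1N1CCCCCC1)c1ccc(NS(C)(=O)=O)c(F)c1`, gives 1.6 nM.
Compound 2, `CC(C(=O)NCc1ccc(C(F)(F)F)cc1N1CCN(C2CCCCC2)CC1)c1ccc(NS(C)(=O)=O)c(F)c1`, gives 13.8 nM.
Compound 3, `CC(C)COc1cc(C(F)(F)F)ccc1CNC(=O)C(C)c1ccc(NS(C)(=O)=O)c(F)c1`, gives 0.8 nM.

Compound 3 has the lowest number of the three. Its nearest neighbour is compound 1, with a 2.0-fold lower number from compound 1 to compound 3 (0.30 log units; within the scatter), a gap that falls within the usual scatter, so the two cannot be ranked against each other. Compound 2 stands furthest away: a 17-fold lower number from compound 2 to compound 3 (1.24 log units; beyond the scatter). Within the data shown here, the only sizeable change seen so far is thus the swap of azepan-1-yl for 4-cyclohexylpiperazin-1-yl, an 8.6-fold higher number from compound 1 to compound 2 (0.94 log units; beyond the scatter), while the swap of azepan-1-yl for isobutoxy hardly moved the number.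

Compound 4, `CCCCSc1cc(C(F)(F)F)ccc1CNC(=O)C(C)c1ccc(NS(C)(=O)=O)c(F)c1`, is the next compound. It differs from compound 3 in one place: butylsulfanyl in place of isobutoxy on an aromatic carbon. Both groups are open chains of the same size, so this resembles the small step from compound 1 to compound 3 rather than the large one involving compound 2. Among the measured compounds shown here, no measured step, however, exchanges an oxygen-linked chain for a sulfur-linked one at this position, so the expectation rests on the tolerance seen there.

The expectation for compound 4 in this assay is a small change at most, a 1.9-fold higher number from compound 3 to compound 4 (0.27 log units; within the scatter), likely within the scatter. Compound 4 is therefore estimated at 1.5 nM, with a range from 0.5 nM to 5 nM.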

Compound 4, inhibition constant: 1.9 nM
Compound 4: middle estimate off by 1.3-fold (0.10 log units), on the low side; measured number inside the range.
By their numbers in this assay, from the lowest: compounds 3, 1 and 4 (each within the scatter of the next, the first and the last beyond it); then compound 2.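

In this assay, replacing isobutoxy with butylsulfanyl, two open chains of the same heavy-atom count, gives a 2.4-fold higher number from compound 3 to compound 4 (0.38 log units; beyond the scatter), so this position responds modestly even to a swap of this kind. Butylsulfanyl cannot be told apart from azepan-1-yl, with a 1.2-fold higher number from compound 1 to compound 4 (0.07 log units; within the scatter), while a 7.3-fold lower number from compound 2 to compound 4 (0.86 log units; beyond the scatter) keeps 4-cyclohexylpiperazin-1-yl as the group that stands apart; chains or rings attached through oxygen, sulfur or nitrogen are therefore all compatible with low numbers here, with compound 2 the one that goes against this. Nothing measured here explains why the number moves with these changes.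

The step from compound 3 to compound 4 changes the linking atom and the branching of the chain together, and the compounds shown do not separate the two, as a straight butoxy chain would. They also leave open whether compound 2 stands apart for its piperazine ring or for the cyclohexyl group on it, a question that a piperazin-1-yl group carrying only a methyl would address.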